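Compound 3 to compound 4: a larger group on nitrogen

This account rests on a few compounds, and the source may have more. Where it says the series, first, only, none or still open, it means among the compounds named here.

In a physicochemical assay for lipophilicity, read by HPLC, at pH 7.5 (a higher number here means a more lipophilic compound, a lower number a more polar compound), compound 3 `CCOc1ccccc1-c1ccc(-c2nc3cnccc3c(NC(C(N)=O)C3CC3)c2C#N)cc1` gives 3, the lowest of the three numbers. Compound 1 `CCOc1ccccc1-c1ccc(-c2nc3cnccc3c(N[C@H](CC)C(=O)N(C)C)c2C#N)cc1` gives 3.7 and compound 2 `CCCCC(Nc1c(C#N)c(-c2ccc(-c3ccccc3OCC)cc2)nc2cnccc12)C(N)=O` gives 3.6, and a number 0.10 log units lower from compound 1 to compound 2 (within the scatter). Compound 4 `CCOc1ccccc1-c1ccc(-c2nc3cnccc3c(NC(CC)CNS(=O)(=O)C3CC3)c2C#N)cc1` carries a group of 11 heavy atoms (7 carbon, 1 nitrogen, 2 oxygen, 1 sulfur; one three-membered non-aromatic ring of carbon only) in place of a group of 7 heavy atoms (5 carbon, 1 nitrogen, 1 oxygen; one three-membered non-aromatic ring of carbon only), on a nitrogen on an aromatic ring. Two measured steps change the same place and are both modest: a number 0.70 log units lower from compound 1 to compound 3 (beyond the scatter), and a number 0.60 log units lower from compound 2 to compound 3 (beyond the scatter). Both run towards the smaller group of compound 3, so the larger group of compound 4 suggests a rise of similar size. For the measured compounds named here, no measured compound contains sulfur, so this guide is loose. The expected change is a number 0.50 log units higher from compound 3 to compound 4 (beyond the scatter). For compound 4 the estimate is 3.5, with an expected range of 3 to 4.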

Compound 4, distribution coefficient: 3.6
Compound 4: middle estimate off by 0.10 log units, on the low side; the range from low to high includes it.
By their numbers in this assay, from the lowest: compound 3; then compounds 2, 4 and 1 (each within the scatter of the next).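

In this assay the larger sulfur-bearing group gives a number 0.60 log units higher from compound 3 to compound 4 (beyond the scatter) but stays level with the two groups without a ring, with no change at the digits printed from compound 2 to compound 4 (within the scatter) and a number 0.10 log units lower from compound 1 to compound 4 (within the scatter) in the same series. Among compounds 1, 2 and 4, a group of 8 or 11 heavy atoms on this nitrogen therefore makes no difference beyond the scatter, and the three-membered carbon ring present in both compound 3 and compound 4 does not by itself go with the low number of compound 3. No available evidence explains these steps. On these data alone, how an amine or a carboxylic acid on this nitrogen-bound chain would read remains open.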